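The source may report more compounds than this note shows. Statements on the series, on what has been measured and on what is new or still open speak of the compounds shown alone.

Within the data shown here, compound 1 `O=[N+]([O-])c1ccc(O)c(/C=N/Nc2nc3ccccc3s2)c1` is the only member of this small set that gives a number in a functional assay on MDA-MB-435 cells (Homo sapiens) for cytotoxicity, read by MTT assay, with a stated time of 72 h; a higher number here means a weaker inhibitor, a lower number a stronger inhibitor: in that test compound 1 gives 14000 nM. Compound 2 `O=C(O)c1ccccc1/C=N/Nc1nc2ccccc2s1` returns only a limit of the assay in this assay, > 16800 nM. Compound 3 `COc1ccc(/C=N/Nc2nc3ccccc3s2)c(OC)c1` likewise returns only a limit in this assay, > 15900 nM. Compound 4 `Oc1ccc(O)c(/C=N/Nc2nc3ccccc3s2)c1` has not yet been measured; it differs from compound 1 by hydroxy in place of nitro on an aromatic carbon. Among the measured compounds shown here, no measured pair shows the effect of such a change, so a step in this assay no larger than the usual scatter, in either direction, is expected, with a fair chance that only a limit is returned. The expected step is a 1.3-fold higher number from compound 1 to compound 4 (0.11 log units; within the scatter). Compound 4 is therefore estimated at 18000 nM, in the range from 7000 nM to 45000 nM.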

Compound 4, half-maximal inhibitory concentration: 6270 nM
For compound 4 the middle estimate is 2.9-fold (0.46 log units) above the measured one; the whole stated range lies above it.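

In this assay, among these compounds, hydroxy in place of nitro on this aromatic carbon, para to a hydroxy group, gives a 2.2-fold lower number from compound 1 to compound 4 (0.35 log units; beyond the scatter), the first measured step at this position. Nitro is therefore not needed here for a measurable number, and of these two compounds the one carrying hydroxy is the stronger. Nothing shown explains why the step runs in this direction. The compounds shown leave open whether an amine at this position would give a lower number still. They also leave open whether plain hydrogen there would match hydroxy or nitro.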